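Swapping a benzyl group for cyclohexyl on the ring nitrogen

This account rests on a few compounds, and the source may have more. Where it says the series, first, only, none or still open, it means among the compounds named here.

Among the compounds with values here, compound 1 `O=C(O)c1cc(-c2cccc(COc3ccc4c(c3)CN(Cc3ccc(C(F)(F)F)cc3)C4=O)c2)ccc1Cl` stands at the top of the three numbers so far: in an ADME assay on microsomes from liver (Rattus norvegicus) for metabolic stability, with a stated time of 60 min (on this read-out higher numbers stand for a more stable compound and lower numbers for a less stable compound), compound 1 gives 100% as the highest value. Compound 4 `O=C(O)c1cc(-c2cccc(COc3ccc4c(c3)CN(C3CCCCC3)C4=O)c2)ccc1Cl` has not been measured. The change from the shared core of compound 1 is cyclohexyl in place of 4-(trifluoromethyl)benzyl on an amide-type nitrogen in a ring and it sits on an amide-type nitrogen in a ring.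

Two measured steps make a similar swap to a plain carbon ring. With cyclobutyl, compound 2 `O=C(O)c1cc(-c2cccc(COc3ccc4c(c3)CN(C3CCC3)C4=O)c2)ccc1Cl` gives 76% in this assay and this is a number 24 percentage points lower from compound 1 to compound 2 (beyond the scatter) in size. With cyclopropyl, compound 3 `O=C(O)c1cc(-c2cccc(COc3ccc4c(c3)CN(C3CC3)C4=O)c2)ccc1Cl` gives 9% and this is a number 91 percentage points lower from compound 1 to compound 3 (beyond the scatter) in size. These two ring swaps therefore differ widely, by a number 67 percentage points lower from compound 2 to compound 3 (beyond the scatter) on their own. Within the data shown here, only two such rings have been measured, so the trend is thin. Cyclohexyl is closer in ring size to the cyclobutyl of compound 2 at 76% than to cyclopropyl, so a modest drop is expected, estimated as a number 28 percentage points lower from compound 1 to compound 4 (beyond the scatter) overall. Compound 4 is estimated at 72% (range 40% to 95%).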

Compound 4, percent of the compound remaining: 1%
Beside the measured number, compound 4's estimate is 71 percentage points above it, outside the stated range (below it).
By their numbers in this assay, from the lowest: compounds 4 and 3 (each within the scatter of the next); then compound 2; then compound 1.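

Cyclohexyl on the amide-type nitrogen in a ring does not keep the stability of the 4-(trifluoromethyl)benzyl group in this assay, with a number 99 percentage points lower from compound 1 to compound 4 (beyond the scatter), so a plain carbon ring is no safe replacement here. Ring size does not order the numbers in a simple way: the step for the larger ring is a number 75 percentage points lower from compound 2 to compound 4 (beyond the scatter), while cyclohexyl and cyclopropyl cannot be told apart, at a number 8 percentage points lower from compound 3 to compound 4 (within the scatter), leaving the cyclobutyl of compound 2 alone among these rings with a high number. Nothing available explains this pattern.

How cyclopentyl on this nitrogen would fit among these rings stays open. So does whether plain benzyl, without the trifluoromethyl group, would hold a number like that of compound 1.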